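A Carbamoyl Group Replaces the Methylamino Group

This account rests on a few compounds, and the source may have more. Where it says the series, first, only, none or still open, it means among the compounds named here.

Measured so far:
compound 1 `Nc1oncc1-c1ccccc1`: 85 nM
compound 2 `CNc1oncc1-c1ccccc1`: 670 nM

In an assay on SW48 cells for inhibition of Tryptophan 2,3-dioxygenase (Homo sapiens), read by fluorescence, with a stated time of 30 min (on this read-out lower numbers stand for an effect already at smaller amounts and higher numbers for an effect only at larger amounts of compound), compound 1 gives 85 nM and compound 2 gives 670 nM. Among the compounds with values here, compound 2 therefore stands at the highest of the two numbers measured, and the single measured step, a 7.9-fold higher number from compound 1 to compound 2 (0.90 log units; beyond the scatter), lies beyond the scatter. Compound 3 `NC(=O)c1oncc1-c1ccccc1` differs from compound 2 by carbamoyl in place of methylamino on an aromatic carbon. Within the data shown here, no measured step covers this particular exchange. Among the measured compounds shown here, the only step available, a 7.9-fold higher number from compound 1 to compound 2 (0.90 log units; beyond the scatter), shows that changing the group on that aromatic carbon from a free amine to a methylated one raised the number, and compound 3 replaces the nitrogen-bearing group altogether with a carbamoyl. For the measured compounds named here, with no direct precedent, the account expects a further rise of moderate size rather than a recovery. The expected step is a 2.2-fold higher number from compound 2 to compound 3 (0.35 log units; beyond the scatter). Compound 3 is expected at 1500 nM, with a range from 300 nM to 8000 nM.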

Compound 3, half-maximal effective concentration: > 25000 nM
Compound 3 ended at the assay's limit (the forecaster's own chance of this, stated with the estimate: 20%); at least 16-fold (1.22 log units) between middle value and limit.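

In this assay compound 3 gives > 25000 nM, which is a limit of the assay and not a number. Carbamoyl in place of methylamino gives an at least 37-fold higher number from compound 2 to compound 3 (1.57 log units; beyond the scatter), and carbamoyl in place of amino gives an at least 290-fold higher number from compound 1 to compound 3 (2.46 log units; beyond the scatter). The earlier compounds showed only a change that stayed measurable on this aromatic carbon next to the ring oxygen, a 7.9-fold higher number from compound 1 to compound 2 (0.90 log units; beyond the scatter), whereas the exchange for carbamoyl takes the number to the limit: the limit of > 25000 nM in this assay, at which 1 of the 3 values shown sits.

Going by these compounds, how far compound 3 lies beyond that limit stays open, so the full size of both new steps is unknown. Also open, on these data alone, is whether dimethylamino or ethylamino, which keep a nitrogen on this carbon, or aminomethyl or a carboxylic acid, which attach through carbon, would give a measurable number.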